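Ortho-halogen swap on the thiourea aryl of compound 3

The compounds below may be only part of what the source reports. "The series", "measured", "known", "first", "only" and "open" are said of these compounds alone.

The shared core carries a 2-chlorobenzamide and a primary amide; the ring amine nitrogen is varied. Compound 1 `NC(=O)c1c(NC(=O)c2ccccc2Cl)sc2c1CCNC2` has that nitrogen unsubstituted and in a functional assay on HeLa cells (Homo sapiens) for antiproliferative activity, with a stated time of 24 h (on this read-out higher numbers stand for weaker inhibition and lower numbers for stronger inhibition), compound 1 gives 45000 nM. Compound 2 `N#Cc1ccccc1CN1CCc2c(sc(NC(=O)c3ccccc3Cl)c2C(N)=O)C1` carries a 2-cyanobenzyl there; in this assay compound 2 gives > 50000 nM, a limit of the assay and not a number (the limit of > 50000 nM in this assay, at which 1 of the 3 values shown sits). Compound 3 `NC(=O)c1c(NC(=O)c2ccccc2Cl)sc2c1CCN(C(=S)Nc1ccccc1Br)C2` carries the (2-bromophenyl)thiourea; in this assay compound 3 gives 24600 nM, the low end of the two numbers shown, with the step of a 1.8-fold lower number from compound 1 to compound 3 (0.26 log units; within the scatter) and the step of an at least 2.0-fold lower number from compound 2 to compound 3 (0.30 log units; that floor lies within the scatter) both inside the scatter, as is an at least 1.1-fold higher number from compound 1 to compound 2 (0.04 log units; that floor lies within the scatter).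

Compound 4 `NC(=O)c1c(NC(=O)c2ccccc2Cl)sc2c1CCN(C(=S)Nc1ccccc1I)C2` differs from compound 3 by iodo in place of bromo on an aromatic carbon. Among the measured compounds shown here, no measured step exchanges one halogen for another, and every step on this nitrogen stays within the scatter, so no step beyond the scatter is expected in this assay; the expected step is a 1.1-fold lower number from compound 3 to compound 4 (0.05 log units; within the scatter). Compound 4 is estimated at 22000 nM, expected between 8000 nM and 60000 nM.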

Compound 4, half-maximal inhibitory concentration: 29000 nM
For compound 4 the middle estimate is 1.3-fold (0.12 log units) below the measured one, within the range that was stated.
By their numbers in this assay, from the lowest: compounds 3, 4 and 1 (each within the scatter of the next). At a limit, above all of these: compound 2.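

The only halogen exchange shown, 2-bromophenyl to 2-iodophenyl on the thiourea, gives a 1.2-fold higher number from compound 3 to compound 4 (0.07 log units; within the scatter), so in this assay these two halogens are not told apart at this position. The (2-iodophenyl)thiourea on the ring amine nitrogen also stays within the scatter of the unsubstituted nitrogen, with a 1.6-fold lower number from compound 1 to compound 4 (0.19 log units; within the scatter), and the comparison with the 2-cyanobenzyl, an at least 1.7-fold lower number from compound 2 to compound 4 (0.23 log units; that floor lies within the scatter), gives only a floor that lies within the scatter. The value of compound 2 is a limit of the assay and not a number: the limit of > 50000 nM in this assay, at which 1 of the 4 values shown sits.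

Still open, going by these compounds, is how a 2-fluorophenyl or 2-methoxyphenyl on the thiourea, or a urea in place of the thiourea, would read in this assay. Also open, on these data alone, is whether any group on this nitrogen can move the number beyond the scatter.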